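The source may hold more compounds than are shown below. What is called first, only, known or untested is meant among the compounds shown, and "the series" means these compounds.

Measured in an ADME assay on microsomes from liver (Mus musculus), read by LC-MS, using NADPH, with a stated time of 30 min, tested at 1 uM; a lower number here means that less of the compound is left, a higher number that more of the compound is left:
- compound 1, `C[C@H](Nc1nc(N)nc(N)c1C#N)c1cc2ccc(F)cn2c(=O)c1-c1ccccc1`: 42%
- compound 2, `C[C@H](Nc1nc(N)ncc1C#N)c1cc2ccc(F)cn2c(=O)c1-c1ccccc1`: 11%
- compound 3, `Cc1cc(F)cc(-c2c([C@H](C)Nc3nc(N)nc(N)c3C#N)cc3ccc(F)cn3c2=O)c1`: its value is a limit of the assay, < 1%

Compound 1 stands highest of the two numbers. The step of a number 31 percentage points lower from compound 1 to compound 2 (beyond the scatter) separates it from compound 2, and the step of a number at least 41 percentage points lower from compound 1 to compound 3 (beyond the scatter) separates it from compound 3, which sits at the limit of < 1% in this assay, at which 1 of the 3 values shown sits.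

Compound 4, `C[C@H](Nc1nc(N)nc(N)c1C#N)c1c(-c2ccccc2)c(=O)n2cc(F)ccc2c1-c1ccc(C(N)=O)cc1`, differs from compound 1 by 4-carbamoylphenyl in place of hydrogen on an aromatic carbon. Neither measured step makes this same change: one removes an amino group, the other enlarges the phenyl, yet both were large and downward. Adding a further aryl group to the core of compound 1 is expected to follow that direction, so the step of a number 22 percentage points lower from compound 1 to compound 4 (beyond the scatter) in this assay is expected to be moderate and downward. Compound 4 is therefore estimated at 20%, between 3% and 45%.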

Compound 4, percent of the compound remaining: 97%
The estimate for compound 4 lay 77 percentage points below the measured number, and the stated range ends below it.
By their numbers in this assay, from the lowest: compound 2; then compound 1; then compound 4. At a limit, below all of these: compound 3.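

Placing 4-carbamoylphenyl on this aromatic carbon of the core of compound 1 gives a number 55 percentage points higher from compound 1 to compound 4 (beyond the scatter) in this assay, the only upward step shown, whereas both earlier changes went downward. This position, two atoms from the ring nitrogen, therefore accepts a large group with more of the compound left, not less. No measured property shown here accounts for this step.

Going by these compounds, it remains open whether the ring or its carbamoyl group carries the step. A plain phenyl, or a carboxylic acid or an amine in place of the carbamoyl group, would separate the two.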